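From Methyl to Butyl on a Shared Core

The compounds below may be only part of what the source reports. "The series", "measured", "known", "first", "only" and "open" are said of these compounds alone.

Measured compounds:
compound 1 `OC[C@@]1(c2ccc(F)cc2)NC[C@@H](O)[C@@H]1O` — 6.6%
compound 2 `CCCCCCCCC[C@]1(CO)NC[C@@H](O)[C@@H]1O` — 0%
compound 3 `C[C@]1(CO)NC[C@@H](O)[C@@H]1O` — 3.8%

In an assay on isolated protein for inhibition of alpha-mannosidase (Canavalia ensiformis), tested at 1000 uM (on this read-out higher numbers stand for more inhibition at the one concentration tested (going by the name of the read-out) and lower numbers for less inhibition), compound 1 gives 6.6%, compound 2 gives 0% and compound 3 gives 3.8%. All three readings are small. Compound 3 stands second highest of the three, yet its distance to compound 1 and its distance to compound 2 both lie within the scatter, so no order among the three can be read from these numbers; the only thing they show together is that none of the three inhibits to any notable degree at the single concentration tested.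

Compound 4 `CCCC[C@]1(CO)NC[C@@H](O)[C@@H]1O` differs from compound 3 in one place: propyl in place of hydrogen on a saturated chain carbon bound to a saturated ring carbon. The same difference, cut one bond further out, reads methyl to butyl.

For the measured compounds named here, no pair of measured compounds differs in exactly one place, so no measured step is available as a guide. The expected step of a number 1.8 percentage points lower from compound 3 to compound 4 (within the scatter) is none beyond the scatter, because compound 2 with its much longer chain gives 0% and compound 3 gives 3.8%, leaving little room for movement in either direction. Compound 4 is therefore expected to give 2%, within a range from 0% to 9%.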

Compound 4, a percentage reported as inhibition, at one concentration (the size of the read-out at that concentration, not a potency): 1.9%
Beside the measured number, compound 4's estimate is 0.1 percentage points above it; the range from low to high includes it.
By their numbers in this assay, from the lowest: compounds 2, 4, 3 and 1 (each within the scatter of the next).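

For the compounds shown here, for the first time, two pairs of measured compounds differ in one place, so chain changes can be read directly in this assay: propyl in place of hydrogen on a saturated chain carbon bound to a saturated ring carbon gives a number 1.9 percentage points lower from compound 3 to compound 4 (within the scatter), and hydrogen in place of pentyl on a saturated chain carbon, four bonds along the chain from a saturated ring carbon, gives a number 1.9 percentage points higher from compound 2 to compound 4 (within the scatter). Both steps lie within the scatter, so among compound 2, compound 3 and compound 4 the length of this chain makes no difference that can be told apart, and all three readings remain small. Nothing at hand explains these readings.

Still open, as far as these compounds go, is whether an amine or a carboxylic acid in place of the propyl would move the reading beyond the scatter, since only plain carbon chains have been compared at this position. Also open, from the compounds shown here alone, is whether these same chains would separate from one another in a read-out that gives a true potency instead of inhibition at a single concentration.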